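Amine swap on the propoxy chain of compound 2

The source may report more compounds than this note shows. Statements on the series, on what has been measured and on what is new or still open speak of the compounds shown alone.

In a functional assay on NCI-H661 cells (Homo sapiens) for cytotoxicity, read by WST assay, with a stated time of 72 h (on this read-out lower numbers stand for stronger inhibition and higher numbers for weaker inhibition), compound 1 `COc1cc2c(Nc3nc4ccc(C(=O)Nc5c(C)cc(C)cc5C)cc4s3)ncnc2cc1OCCCN1CCC(C)CC1` gives 7700 nM. Compound 2 `COc1cc2c(Nc3nc4ccc(C(=O)Nc5c(C)cccc5C)cc4s3)ncnc2cc1OCCCN1CCCC1` reaches only a limit of this assay, > 100000 nM. This is the limit of > 100000 nM in this assay, at which 1 of the 2 values shown sits. Among the measured compounds shown here, compound 1 and compound 2 differ in more than one place, so their two values show only that compound 1 registers a number where compound 2 does not.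

Compound 3 `CCN(CC)CCCOc1cc2ncnc(Nc3nc4ccc(C(=O)Nc5c(C)cccc5C)cc4s3)c2cc1OC` carries diethylamino in place of pyrrolidin-1-yl on a saturated chain carbon, three bonds along the chain from an oxygen on an aromatic ring. For the measured compounds named here, no measured step separates one amine on this chain from another, so the size of the change is open; with compound 2 at a limit, any step from it can only be read as a move toward a measurable number or none at all. The step of an at least 1.2-fold lower number from compound 2 to compound 3 (0.09 log units; that floor lies within the scatter) is expected to stay within the scatter of this assay. Compound 3 is estimated at 80000 nM, with a range from 20000 nM to 300000 nM, and a limit rather than a number is quite possible.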

Compound 3, half-maximal inhibitory concentration: 66500 nM
For compound 3 the middle estimate is 1.2-fold (0.08 log units) above the measured one; measured number inside the range.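

Going from 3-(pyrrolidin-1-yl)propyl to 3-(diethylamino)propyl gives the first comparison on this chain that differs in one place, and in this assay it reads as an at least 1.5-fold lower number from compound 2 to compound 3 (0.17 log units; that floor lies within the scatter). With the ring opened and the hydrogen-bond donor and acceptor counts unchanged, compound 3 registers a number, 66500 nM, so the amine at this place can be varied with a measurable result. The step stays a floor, and its true size cannot be stated, because compound 2 sits at a limit: the limit of > 100000 nM in this assay, at which 1 of the 3 values shown sits.

On these data alone, whether the true gap between these two amines lies beyond the scatter remains open. Compound 1 differs from both in more than one place and gives no readable step, and a morpholin-4-yl group, a dimethylamino group or a longer chain at this place remains untested in the compounds shown.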